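Swapping cyclohexyl for 3-bromophenyl in compound 3

The compounds below may be only part of what the source reports. "The series", "measured", "known", "first", "only" and "open" are said of these compounds alone.

Values so far in a functional assay on PC-9 cells (Homo sapiens) for inhibition, read by MTT assay, with a stated time of 72 h (a lower number here means a stronger inhibitor, a higher number a weaker inhibitor), are these:

Compound 1 `Cc1cc(Nc2cc(-c3ccccc3)[nH]n2)n2nc(SCc3ccc([N+](=O)[O-])cc3)nc2n1` gives 7980 nM
Compound 2 `Cc1cc(Nc2ccn(Cc3cccc4ccccc34)n2)n2nc(SCc3ccc(Br)cc3)nc2n1` gives 5660 nM
Compound 3 `Cc1cc(Nc2cc(-c3ccccc3)[nH]n2)n2nc(SCC3CCCCC3)nc2n1` gives > 50000 nM (a limit, not a number)

Compound 3 stands at the limit of > 50000 nM in this assay, at which 1 of the 3 values shown sits, and has no exact value to start from. Compound 4 `Cc1cc(Nc2cc(-c3ccccc3)[nH]n2)n2nc(SCc3cccc(Br)c3)nc2n1` differs from compound 3 in one place, with 3-bromophenyl in place of cyclohexyl on a saturated chain carbon bound to a sulfur, counted as 3-bromophenyl in place of cyclohexyl on a saturated chain carbon bound to a sulfur in full.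

Within the data shown here, one measured step bears on this change, namely an at least 6.2-fold higher number from compound 1 to compound 3 (0.79 log units; beyond the scatter) for cyclohexyl in place of 4-nitrophenyl at that same place. Compound 4 runs that swap in the opposite direction, though with a different aromatic group, so a lower number is expected in this assay and the gain should be at least modest. Among the measured compounds shown here, compound 2 differs from the others in more than one place and offers no clean step. For the measured compounds named here, no measured step isolates the 3-bromophenyl group itself, so this expectation rests on a single comparison.

The estimated change is an at least 6.2-fold lower number from compound 3 to compound 4 (0.79 log units; beyond the scatter) and it carries that uncertainty. For compound 4 the estimated value is 8000 nM with an expected range from 2500 nM to 25000 nM in this assay.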

Compound 4, half-maximal inhibitory concentration: 8900 nM
The estimate for compound 4 lay 1.1-fold (0.05 log units) below the measured number; measured number inside the range.
By their numbers in this assay, from the lowest: compounds 2, 1 and 4 (each within the scatter of the next). At a limit, above all of these: compound 3.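

In this assay, placing 3-bromophenyl rather than cyclohexyl on a saturated chain carbon bound to a sulfur gives an at least 5.6-fold lower number from compound 3 to compound 4 (0.74 log units; beyond the scatter), so a second aromatic group at this place, alongside the 4-nitrophenyl of compound 1, gives a measurable value where cyclohexyl does not. Exchanging one aromatic group for the other gives a 1.1-fold higher number from compound 1 to compound 4 (0.05 log units; within the scatter), so these two groups, which carry different substituents, cannot be told apart in this assay, and the exact substituent does not show up as a difference between them. Compound 3 carries a limit and not a number, so the true size of the step from cyclohexyl remains unknown because only a bound is available: the limit of > 50000 nM in this assay, at which 1 of the 4 values shown sits.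

The compounds shown do not separate the contribution of the aromatic ring from that of its substituent, so it remains open whether a plain phenyl group, with neither bromine nor nitro, would behave like compound 1 and compound 4. Going by these compounds, it is equally open how a ring carrying a basic amine, or a carboxylic acid, or an open hexyl chain in place of the ring, would read at this place.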